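Swapping the Furan for a Fluorophenyl on the Amide

The source may hold more compounds than are shown below. What is called first, only, known or untested is meant among the compounds shown, and "the series" means these compounds.

Of the compounds shown here, two built on one shared core have so far been measured in an assay on CHO cells for displacement of a labelled ligand from adenosine receptor A3 (Homo sapiens), read by scintillation counting; on this read-out higher numbers stand for weaker inhibition and lower numbers for stronger inhibition. Compound 1 `O=C(Nc1nc(-c2ccccc2)nc2c1nnn2Cc1ccccc1)c1ccoc1` gives 1640 nM in this assay. Compound 2 `O=C(Nc1nc(-c2ccccc2)nc2c1nnn2Cc1ccccc1)c1cccc(F)c1` gives 5810 nM. Of these two numbers, compound 1 stands lowest, so it is the stronger binder of the pair, and the step of a 3.5-fold higher number from compound 1 to compound 2 (0.55 log units; beyond the scatter) came with 3-fluorophenyl in place of furan-3-yl on a carbonyl carbon.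

Compound 3 `O=C(Nc1nc(-c2ccccc2)nc2c1nnn2Cc1ccccc1)c1ccccc1F` has not yet been measured. It differs from compound 1 in one place: 2-fluorophenyl in place of furan-3-yl on a carbonyl carbon. Within the data shown here, the only measured step that bears on this change is a 3.5-fold higher number from compound 1 to compound 2 (0.55 log units; beyond the scatter), in which the same furan-3-yl gave way to a closely related fluorophenyl and the number rose beyond the scatter. A rise of comparable size, in the same direction, is therefore expected here, with some allowance for the two fluorophenyl groups not being identical.

Compound 3 is estimated to give 4000 nM, within a range from 1500 nM to 10000 nM, which is expected to mean a step of a 2.4-fold higher number from compound 1 to compound 3 (0.39 log units; beyond the scatter).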

Compound 3, inhibition constant: 5300 nM
Compound 3: middle estimate off by 1.3-fold (0.12 log units), on the low side, within the range that was stated.
By their numbers in this assay, from the lowest: compound 1; then compounds 3 and 2 (each within the scatter of the next).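

In this assay the swap of furan-3-yl for 2-fluorophenyl on the carbonyl carbon gives a 3.2-fold higher number from compound 1 to compound 3 (0.51 log units; beyond the scatter) and so closely repeats the rise already seen with 3-fluorophenyl, which means that this loss of binding is not peculiar to a single fluorophenyl group. Comparing the two fluorophenyl groups directly gives a 1.1-fold lower number from compound 2 to compound 3 (0.04 log units; within the scatter) and shows that, in this pair, 2-fluorophenyl and 3-fluorophenyl cannot be told apart, so compound 1 with its furan-3-yl group still binds more strongly than either compound 3 or compound 2. Nothing available explains why furan-3-yl on this carbonyl carbon outperforms both fluorophenyl groups.

The compounds shown leave open whether the difference follows the furan ring itself or the fluorine, a question that plain phenyl, thiophen-3-yl or furan-2-yl on the same carbonyl carbon would help to settle. They also leave open how this position responds to groups of a wholly different kind, such as a cyclohexyl ring, a short alkyl chain or a chain ending in an amine.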